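The source may report more compounds than this note shows. Statements on the series, on what has been measured and on what is new or still open speak of the compounds shown alone.

Three compounds sharing one core and differing only in the group on a carbonyl carbon have been measured in a functional assay on MDA-MB-231 cells (Homo sapiens) for antiproliferative activity, read by MTT assay, with a stated time of 72 h; a lower number here means a stronger inhibitor, a higher number a weaker inhibitor. Compound 1 `CC1=CC[C@H]2[C@H](CC[C@]2(C)O)C(C)(C)[C@@H]1CC[C@H]1[C@]2(C)CC[C@H](OC(=O)c3ccncc3)C(C)(C)O[C@H]2CC[C@@]1(C)O` gives 18000 nM, compound 2 `CC1=CC[C@H]2[C@H](CC[C@]2(C)O)C(C)(C)[C@@H]1CC[C@H]1[C@]2(C)CC[C@H](OC(=O)c3ccc(C)cc3)C(C)(C)O[C@H]2CC[C@@]1(C)O` gives 33400 nM, and compound 3 `CC1=CC[C@H]2[C@H](CC[C@]2(C)O)C(C)(C)[C@@H]1CC[C@H]1[C@]2(C)CC[C@H](OC(=O)c3ccc(F)cc3)C(C)(C)O[C@H]2CC[C@@]1(C)O` gives 11300 nM. Compound 3 therefore stands apart from compound 2 but not from compound 1, as the steps show: a 3.0-fold lower number from compound 2 to compound 3 (0.47 log units; beyond the scatter) and a 1.6-fold lower number from compound 1 to compound 3 (0.20 log units; within the scatter).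

The next compound, compound 4 `CC1=CC[C@H]2[C@H](CC[C@]2(C)O)C(C)(C)[C@@H]1CC[C@H]1[C@]2(C)CC[C@H](OC(=O)c3ccccc3[N+](=O)[O-])C(C)(C)O[C@H]2CC[C@@]1(C)O`, carries 2-nitrophenyl in place of 4-fluorophenyl on a carbonyl carbon. Going by the values given here, no measured compound carries the entering group, so the evidence is indirect. It comes from the three exchanges at this same place, the third being a 1.9-fold higher number from compound 1 to compound 2 (0.27 log units; within the scatter). Of these, only the exchange between compound 2 and compound 3 goes beyond the scatter, and only modestly. A step no larger than that one is therefore expected in this assay, probably within the scatter, and the direction is uncertain, with a slight lean towards a higher number. The step expected is a 1.5-fold higher number from compound 3 to compound 4 (0.18 log units; within the scatter). The estimated value for compound 4 is 17000 nM, with an expected range from 7000 nM to 42000 nM.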

Compound 4, half-maximal inhibitory concentration: 38700 nM
Estimate against measurement, compound 4: 2.3-fold (0.36 log units) below; the measured number falls inside the stated range.
By their numbers in this assay, from the lowest: compounds 3, 1, 2 and 4 (each within the scatter of the next, the first and the last beyond it).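

Within this assay, replacing 4-fluorophenyl with 2-nitrophenyl gives a 3.4-fold higher number from compound 3 to compound 4 (0.53 log units; beyond the scatter), so this exchange joins the one between compound 2 and compound 3 as a modest step at this place that goes beyond the scatter. The other two new steps separate the aryl groups further: 2-nitrophenyl in place of pyridin-4-yl gives a 2.2-fold higher number from compound 1 to compound 4 (0.33 log units; beyond the scatter), also modest and beyond the scatter, whereas 2-nitrophenyl in place of 4-methylphenyl gives a 1.2-fold higher number from compound 2 to compound 4 (0.06 log units; within the scatter), so compound 4 cannot be told apart from compound 2 and the position has so far tolerated this larger group without a step exceeding a modest size. Nothing available here accounts for these differences in the numbers.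

The compounds shown leave open whether the step to compound 4 follows from the nitro group itself or from where it sits on the ring, as the 4-fluorophenyl and 2-nitrophenyl groups differ in both respects. Also open, on these data alone, is how this assay would read with a phenyl ring carrying an amine or a carboxylic acid, or with a longer alkyl chain on the carbonyl carbon in place of an aromatic ring.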